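Trifluoromethoxy in place of butyl: compound 3 to compound 4

The source may report more compounds than this note shows. Statements on the series, on what has been measured and on what is new or still open speak of the compounds shown alone.

Measured so far in a functional assay on HEK293 cells for antagonist activity at transient receptor potential cation channel subfamily V member 1 (Rattus norvegicus); a higher number here means a weaker inhibitor, a lower number a stronger inhibitor:
compound 1 `Cc1ccc(NC(=O)N2CCN(c3ncccc3C(F)(F)F)CC2)cc1`, 1550 nM
compound 2 `CC(C)(C)c1ccc(NC(=S)N2CCN(c3ncccc3C(F)(F)F)CC2)cc1`, 441 nM
compound 3 `CCCCc1ccc(NC(=O)N2CCN(c3ncccc3Cl)CC2)cc1`, 203 nM

Compound 3 holds the lowest number of the three in this assay. Its nearest neighbour is compound 2, whose gap to compound 3 lies beyond the scatter; compound 1 sits furthest away, also beyond the scatter.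

Compound 4 `O=C(Nc1ccc(OC(F)(F)F)cc1)N1CCN(c2ncccc2Cl)CC1` is not yet measured. It differs from compound 3 by trifluoromethoxy in place of butyl on an aromatic carbon, the group sitting on an aromatic carbon of the six-membered carbon-only ring. Going by the values given here, no two measured compounds differ in one place only, so no step of this kind has been observed; the other two compounds each differ from compound 3 in more than one place.

The step of a 1.5-fold higher number from compound 3 to compound 4 (0.17 log units; within the scatter) is expected to be small, in either direction, and probably not beyond the scatter. Compound 4 is therefore estimated at 300 nM, in the range 80 nM to 1200 nM.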

Compound 4, half-maximal inhibitory concentration: 261 nM
For compound 4 the middle estimate is 1.1-fold (0.06 log units) above the measured one, and the stated range covers the measured number.
By their numbers in this assay, from the lowest: compounds 3, 4 and 2 (each within the scatter of the next, the first and the last beyond it); then compound 1.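

In this assay, going by these compounds alone, trifluoromethoxy in place of butyl on an aromatic carbon, para to a large group, gives a 1.3-fold higher number from compound 3 to compound 4 (0.11 log units; within the scatter), the first step between compounds differing in one place. At this position, the two groups cannot be told apart, although they share neither atom make-up nor hydrogen-bond acceptor count. Nothing measured bears on why they read alike.

Still open, on these data alone, is whether an amine, a carboxylic acid or a longer chain on this carbon would stay within the scatter of compound 3. As far as these compounds go, whether the step carries over to the core of compound 1 is also open.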